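This account rests on a few compounds, and the source may have more. Where it says the series, first, only, none or still open, it means among the compounds named here.

Three chalcone-type compounds are compared here. Compound 1 `CC(C)(C)c1ccc(C(=O)/C=C/c2ccc([N+](=O)[O-])o2)cc1` carries a tert-butyl group on one aromatic ring and a nitrofuran on the other. Compound 2 `CN(C)c1ccc(/C=C/C(=O)c2ccc(-c3ccccc3)cc2)cc1` has a dimethylamino group and a biphenyl instead. Compound 3 `O=C(/C=C/c1ccc([N+](=O)[O-])o1)c1ccc(Br)cc1` has not yet been tested.

In an ADME assay on Vero cells (Chlorocebus sabaeus) for cytotoxicity, read by resazurin assay, with a stated time of 72 h (on this read-out lower numbers stand for higher toxicity in this test and higher numbers for lower toxicity in this test), compound 1 gives > 100000 nM, which is a limit of the assay rather than a measured number. For compound 2 the result in this assay is "not determined" (no result reported). So compound 1 stands at the limit, as shown by the limit of > 100000 nM in this assay, at which 1 of the 2 values shown sits, and no second number exists to set it against.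

The change from compound 1 to compound 3 is bromo in place of tert-butyl on an aromatic carbon. Going by the values given here, with nothing more than a limit for compound 1, no measured step can guide the expectation, and the step from the tert-butyl to the bromo compound is expected to be small, likely none beyond the scatter, so that a number no higher from compound 1 to compound 3 (the limit leaves the size open) stays close to flat. Compound 3 is therefore estimated at 100000 nM, in a range from 30000 nM to 300000 nM, and it may well again return only a limit.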

Compound 3, half-maximal cytotoxic concentration: > 100000 nM
Compound 3 ended at the assay's limit; the forecaster's own chance of this, stated with the estimate: 65%; the middle value lies on the limit itself.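

Compound 1 and compound 3 both end at a limit rather than a measured number in this assay, so no step can be read between them: the limit of > 100000 nM in this assay, at which 2 of the 3 values shown sit.

As far as these compounds go, what stays open is the actual half-maximal cytotoxic concentration of compound 1 and compound 3, and so whether bromo in place of tert-butyl makes any difference in this assay.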